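The source may hold more compounds than are shown below. What is called first, only, known or untested is meant among the compounds shown, and "the series" means these compounds.

Measured compounds: compound 1 `Oc1cccc(-c2cc(-c3ccccc3O)nc(-c3ccccc3O)c2)c1`, 5400 nM; compound 2 `Oc1cccc(-c2cc(-c3cccc(O)c3)nc(-c3ccccc3O)c2)c1`, > 50000 nM; compound 3 `Oc1ccc(-c2cc(-c3cccc(O)c3)cc(-c3ccccc3O)n2)cc1`, > 50000 nM.

Going by the values given here, in a functional assay on DU-145 cells (Homo sapiens) for cytotoxicity, read by CCK-8 assay, with a stated time of 4 days (on this read-out lower numbers stand for stronger inhibition and higher numbers for weaker inhibition), compound 1 gives 5400 nM, the only proper number in the set. For compound 2 the result > 50000 nM is a limit of the assay and not a number. For compound 3 likewise > 50000 nM is a limit. Both comparisons to compound 1 therefore read as an at least 9.2-fold higher number from compound 1 to compound 2 (0.96 log units; beyond the scatter) and an at least 9.2-fold higher number from compound 1 to compound 3 (0.96 log units; beyond the scatter), each touching a 2-hydroxyphenyl group, and the pair compound 2 to compound 3 gives a step that the two limits leave unreadable from compound 2 to compound 3, since (the limit of > 50000 nM in this assay, at which 2 of the 3 values shown sit).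

Compound 4 `Oc1ccc(-c2cc(-c3ccccc3O)nc(-c3ccccc3O)c2)cc1` is not yet measured. It keeps both 2-hydroxyphenyl groups and differs from compound 1 only as 4-hydroxyphenyl in place of 3-hydroxyphenyl on an aromatic carbon. Among the compounds with values here, no measured step bears on this exact change; the two readable steps alter a different group, and the only step between 3-hydroxyphenyl and 4-hydroxyphenyl is unreadable. The retained 2-hydroxyphenyl groups argue against a collapse, the limits elsewhere argue for caution, so a weaker value is expected, a 2.2-fold higher number from compound 1 to compound 4 (0.35 log units; beyond the scatter). Compound 4 is estimated at 12000 nM in this assay, within 3000 nM to 50000 nM.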

Compound 4, half-maximal inhibitory concentration: > 50000 nM
Compound 4 was reported as a limit; the forecaster's own chance of this, stated with the estimate: 35%; middle value at least 4.1-fold (0.61 log units) from the limit.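

In this assay compound 4 gives > 50000 nM, which is a limit of the assay and not a number. Exchanging 3-hydroxyphenyl for 4-hydroxyphenyl opposite the ring nitrogen gives an at least 9.2-fold higher number from compound 1 to compound 4 (0.96 log units; beyond the scatter), so this position responds to the change even with both 2-hydroxyphenyl groups retained, a reading the unreadable pair of compound 2 and compound 3 could not give. Retaining the two 2-hydroxyphenyl groups is therefore not enough on its own to keep a measurable value, and the step gives only a lower bound on the loss: the limit of > 50000 nM in this assay, at which 3 of the 4 values shown sit.

On these data alone, whether an amine or a carboxylic acid in place of the hydroxyl on the 3-hydroxyphenyl group of compound 1 would keep a measurable value remains open. The steps among compound 2, compound 3 and compound 4 cannot be read.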